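The compounds below may be only part of what the source reports. "The series", "measured", "known", "first", "only" and "open" are said of these compounds alone.

Compound 2, with the structure `CC1(C)CC12NC(=O)N(NC(=O)c1ccc(F)cc1)C2=O`, gives 300 mg/kg in a functional assay on the whole organism (Hindlimb) for inhibition, with Mus musculus as the target, with a stated time of 4 h; on this read-out higher numbers stand for an effect only at larger amounts of compound and lower numbers for an effect already at smaller amounts. That number stands level with compound 3, whose structure is `COc1ccc(C(=O)NN2C(=O)NC3(CC3(C)C)C2=O)cc1OC` and whose value is 300 mg/kg, and together these two are the highest of the three measured numbers. Among the measured compounds shown here, compound 1, with the structure `CC(C)(C)c1ccc(C(=O)NN2C(=O)NC3(CC3(C)C)C2=O)cc1`, gives 100 mg/kg, and the step of a 3.0-fold higher number from compound 1 to compound 2 (0.48 log units; beyond the scatter) is the only measured change at this position: exchanging tert-butyl for fluoro on the aromatic carbon pushed the number up. Compound 4, with the structure `CN(C)c1ccc(C(=O)NN2C(=O)NC3(CC3(C)C)C2=O)cc1`, carries the change (dimethylamino in place of fluoro on an aromatic carbon), a group sitting para to a large group. For the measured compounds named here, no measured step covers dimethylamino itself, so the only guide is the tert-butyl to fluoro step, which ran against fluoro by a modest margin. Undoing fluoro in favour of another three-heavy-atom group is therefore expected to move the number back down by a modest amount, as in the estimated step of a 1.5-fold lower number from compound 2 to compound 4 (0.18 log units; within the scatter). Compound 4 is thus expected to give about 200 mg/kg, within a range from 70 mg/kg to 400 mg/kg.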

Compound 4, minimum effective dose: 300 mg/kg
Compound 4: the middle estimate sits 1.5-fold (0.18 log units) below what was measured; measured number inside the range.
By their numbers in this assay, from the lowest: compound 1; then compounds 2, 3 and 4 (each within the scatter of the next).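

In this assay, dimethylamino in place of fluoro gives no change at the digits printed from compound 2 to compound 4 (within the scatter), so swapping a single fluorine for this larger group, which also counts one hydrogen-bond acceptor, leaves the read-out unmoved. Dimethylamino in place of tert-butyl gives a 3.0-fold higher number from compound 1 to compound 4 (0.48 log units; beyond the scatter), which matches the earlier fluoro step, so of these three groups at this position tert-butyl alone stands apart from the other two. Nothing measured on these compounds bears on why tert-butyl differs.

As far as these compounds go, it remains open whether the lower number belongs to tert-butyl alone or would also appear with another carbon-only group, such as isopropyl or a longer alkyl chain. Also open, from the compounds shown here alone, is how a primary amine or a carboxylic acid would read at this position.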